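A few compounds are considered here, and "the series" means these few. Any claim that something is new, unique, unknown or untested is made for them only; others in the source may bear on it.

Working notes on the series in an assay on CHO-K1 cells for inhibition of sodium-dependent dopamine transporter (Homo sapiens); a lower number here means a stronger inhibitor, a higher number a weaker inhibitor.

Compound 3 `Clc1ccc(C[C@@]23CCCC[C@@H]2CNC3)cc1Cl` gives 158 nM in this assay and stands lowest of the two compounds with a single number there. For the measured compounds named here, compound 1 `CN1C[C@H]2CCCC[C@@]2(Cc2ccc(Cl)c(Cl)c2)C1` gives 479 nM; the step of a 3.0-fold lower number from compound 1 to compound 3 (0.48 log units; beyond the scatter) is the only one-place change measured in the set. Compound 2 `CN1C[C@@H]2CCCC[C@]2(c2cccc3ccccc23)C1` gives 1320 nM; 3310 nM (2 entries), and the several entries of compound 2 in this assay, 1320 nM; 3310 nM (2 entries) shows how far repeats of one compound can spread in this assay.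

Compound 4 `Clc1ccc(C[C@]23CCCC[C@H]2CNC3)cc1Cl` differs from compound 3 by the two compounds have the same atoms and bonds and differ only in configuration as drawn: 2 of 2 stereo elements differ (all stereocentres are inverted: mirror images); a stereocentre at a saturated ring carbon is drawn S in compound 3 and R in compound 4; a stereocentre at a saturated ring carbon is drawn S in compound 3 and R in compound 4. Going by the values given here, no measured step inverts a stereocentre, so neither the amine change from compound 1 to compound 3 nor the spread of compound 2 bears directly on it; they only set the scale of scatter. The step of a 2.8-fold higher number from compound 3 to compound 4 (0.45 log units; beyond the scatter) is therefore an estimate without a precedent in the data, and is set toward a higher number with a broad range. Compound 4 is expected at 450 nM, between 80 nM and 2500 nM.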

Compound 4, half-maximal inhibitory concentration: 501 nM
For compound 4 the middle estimate is 1.1-fold (0.05 log units) below the measured one; low and high end bracket the measured number.
By their numbers in this assay, from the lowest: compound 3; then compounds 1 and 4 (each within the scatter of the next).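

In this assay, for the compounds shown here, inverting both stereocentres of the shared core gives a 3.2-fold higher number from compound 3 to compound 4 (0.50 log units; beyond the scatter), the first evidence that this assay separates a pair of mirror images. The step can be assigned to configuration alone, because no atom or bond changes: the fact that compounds 3 and 4 differ only in the configuration as drawn. The step is modest and lies beyond the scatter, but repeats of a single compound can also spread some way in this assay: the several entries of compound 2 in this assay, 1320 nM; 3310 nM (2 entries).

Which of the two stereocentres carries the step remains open, since the pair inverts both at once. Also open, from the compounds shown here alone, is whether the same order of mirror images holds with methyl or an ethyl group on the ring nitrogen, or with a benzyl group carrying a single chlorine.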